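Following a Longer Chain on the Carbonyl

The source may report more compounds than this note shows. Statements on the series, on what has been measured and on what is new or still open speak of the compounds shown alone.

Compound 1 `COCC(=O)N(Cc1ccc(OC)c(O)c1)c1cc(OC)c(OC)c(OC)c1`: 460 nM
Compound 2 `COc1ccc(CNc2cc(OC)c(OC)c(OC)c2)cc1Cl`: 47800 nM
Compound 3 `C/C=C/C(=O)N(Cc1cc(OC)c(OC)c(OC)c1)c1ccc(OC)c(O)c1`: 9160 nM

These three compounds were tested in a functional assay on KYSE-450 cells (Homo sapiens) for inhibition, read by MTT assay, with a stated time of 48 h; a lower number here means a stronger inhibitor, a higher number a weaker inhibitor. Compound 1 has the lowest number of the three, so it is the strongest inhibitor in this small set. Its nearest neighbour on the scale is compound 3 and its furthest is compound 2, and both gaps lie well beyond the usual scatter of repeat measurements.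

The next compound to be measured is compound 4 `CCC/C=C/C(=O)N(Cc1ccc(OC)c(O)c1)c1cc(OC)c(OC)c(OC)c1`. It keeps the core of compound 1 and changes one group: pent-1-en-1-yl in place of methoxymethyl on a carbonyl carbon. Put simply, pent-1-en-1-yl stands in place of methoxymethyl on a carbonyl carbon.

For the measured compounds named here, no two measured compounds differ in only one place, so no measured step can serve as a direct guide. The closest hint is compound 3, whose carbonyl also carries a chain with a double bond and which gives 9160 nM. It differs from compound 4 elsewhere too, so this hint is weak. A moderate loss of strength therefore seems likely, with a higher number in this assay and a step beyond the scatter. The expected change is a 4.3-fold higher number from compound 1 to compound 4 (0.64 log units; beyond the scatter). For compound 4 the estimate is 2000 nM, with an expected range from 350 nM to 11000 nM.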

Compound 4, half-maximal inhibitory concentration: 57 nM
Compound 4: the middle estimate sits 35-fold (1.55 log units) above what was measured; measured number outside the range, below it.
By their numbers in this assay, from the lowest: compound 4; then compound 1; then compound 3; then compound 2.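

For the compounds shown here, compound 4 gives the first step in this set that can be read at a single position: on a carbonyl carbon whose other neighbour is an amide-type nitrogen, pent-1-en-1-yl in place of methoxymethyl gives an 8.1-fold lower number from compound 1 to compound 4 (0.91 log units; beyond the scatter) in this assay. The number at this position therefore responds to the group placed there, and the shared core keeps its inhibition, and gains strength, when a chain with an oxygen and one hydrogen-bond acceptor gives way to a longer all-carbon chain with one double bond. Nothing available on these compounds accounts for the lower number, and this single step cannot say which feature of the new chain matters.

The compounds shown leave open whether the chain length or the double bond goes with the gain, a question that a saturated pentyl chain or a longer chain with the same double bond on this carbonyl could help separate. As far as these compounds go, it also remains open how a chain ending in an amine or a carboxylic acid would read at this position, in this same assay.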